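A few compounds are considered here, and "the series" means these few. Any claim that something is new, unique, unknown or untested is made for them only; others in the source may bear on it.

Three ureas built around a benzothiazolylmethoxy-substituted tolyl core were tested in an assay on isolated protein for inhibition of Polyunsaturated fatty acid 5-lipoxygenase (Homo sapiens), read by HPLC, with a stated time of 10 min; on this read-out lower numbers stand for stronger inhibition and higher numbers for weaker inhibition. Compound 1 `Cc1cc(OCc2nc3ccccc3s2)ccc1NC(=O)Nc1ccccc1Cl` gives 830 nM in this assay. Compound 2 `Cc1cc(OCc2nc3ccccc3s2)ccc1NC(=O)Nc1cccc(Cl)c1` carries 3-chlorophenyl in place of 2-chlorophenyl on an amide-type nitrogen and gives 160 nM, so the change gives a 5.2-fold lower number from compound 1 to compound 2 (0.71 log units; beyond the scatter). Compound 3 `Cc1cc(NC(=O)Nc2ccccc2Cl)ccc1OCc1nc2ccccc2s1` has a core that differs from that of compound 1 in a way that is not broken down here. In this assay compound 3 gives 680 nM. Its number and that of compound 1 sit within the usual scatter of each other, while compound 2 is separated from both beyond the scatter.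

Compound 4 `Cc1cc(NC(=O)Nc2cccc(Cl)c2)ccc1OCc1nc2ccccc2s1` has not yet been measured in this assay. It differs from compound 3 by 3-chlorophenyl in place of 2-chlorophenyl on an amide-type nitrogen, the same change that turns compound 1 into compound 2, made at the same place. Since compound 3 gives 680 nM and the earlier change gave a 5.2-fold lower number from compound 1 to compound 2 (0.71 log units; beyond the scatter), compound 4 is expected to show a 4.5-fold lower number from compound 3 to compound 4 (0.66 log units; beyond the scatter). On that basis compound 4 is estimated at 150 nM, with a likely range from 60 nM to 400 nM.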

Compound 4, half-maximal inhibitory concentration: 2090 nM
For compound 4 the middle estimate is 14-fold (1.14 log units) below the measured one; the whole stated range lies below it.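

On the core of compound 3, 3-chlorophenyl in place of 2-chlorophenyl on an amide-type nitrogen gives a 3.1-fold higher number from compound 3 to compound 4 (0.49 log units; beyond the scatter) in this assay, so the change that strengthened inhibition on the core of compound 1 weakens it here, and the two steps differ in direction as well as in size: the same change on two cores in this assay, a 5.2-fold lower number (0.71 log units; beyond the scatter) from compound 1 to compound 2 and a 3.1-fold higher number (0.49 log units; beyond the scatter) from compound 3 to compound 4, 16-fold (1.20 log units) apart, beyond the scatter of two such steps This shows that, for these two cores, the result of this change depends on the core carrying it, and a step read on one core cannot simply be transferred to the other. It does not show why the two cores part ways, and with a single pair on each core it does not show how far the reversal extends within the series.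

The compounds shown leave open whether the two cores would also diverge with a plain phenyl or a methoxyphenyl on that nitrogen. They also leave open whether the reversal would persist if an ethyl group or a chlorine replaced the methyl group of the core.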